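Bromo in Place of Hydrogen on a Nitrostyryl Cyclohexanone

A few compounds are considered here, and "the series" means these few. Any claim that something is new, unique, unknown or untested is made for them only; others in the source may bear on it.

Measured compounds:
compound 1 `COc1cc(/C=C2\CCC/C(=C\c3cccc([N+](=O)[O-])c3)C2=O)cc(Br)c1OC`, 4.72 ug/mL
compound 2 `COc1cccc(/C=C2\CCC/C(=C\c3ccc([N+](=O)[O-])cc3)C2=O)c1`, 5.82 ug/mL
compound 3 `COc1cc(/C=C2\CCC/C(=C\c3ccc([N+](=O)[O-])cc3)C2=O)ccc1O`, 7.05 ug/mL

In a functional assay on MCF7 cells (Homo sapiens) for cytotoxicity, read by MTT assay (on this read-out higher numbers stand for weaker inhibition and lower numbers for stronger inhibition), compound 3 gives the highest number of the three, yet its gaps to compound 2 and to compound 1 both lie within the scatter. Among the measured compounds shown here, the one step measured in a single place, a 1.2-fold higher number from compound 2 to compound 3 (0.08 log units; within the scatter), shows that adding a hydroxy group left this assay essentially unchanged. Compound 4 `COc1cc(/C=C2\CCC/C(=C\c3ccc([N+](=O)[O-])cc3)C2=O)cc(Br)c1O` differs from compound 3 by bromo in place of hydrogen on an aromatic carbon. For the measured compounds named here, no measured step adds a bromo group alone; compound 1, which carries a bromo group, differs from compound 3 in more than one place, and its value in this assay sits close to that of compound 3. Compound 4 is therefore expected to show a 1.1-fold lower number from compound 3 to compound 4 (0.04 log units; within the scatter), no step beyond the scatter. The estimate for compound 4 is 6.5 ug/mL, ranging from 3.5 ug/mL to 12 ug/mL.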

Compound 4, half-maximal inhibitory concentration: 4.93 ug/mL
The estimate for compound 4 lay 1.3-fold (0.12 log units) above the measured number, within the range that was stated.
By their numbers in this assay, from the lowest: compounds 1, 4, 2 and 3 (each within the scatter of the next).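

In this assay the first step measured for bromo alone, on an aromatic carbon ortho to a hydroxy group, is a 1.4-fold lower number from compound 3 to compound 4 (0.16 log units; within the scatter) and so leaves compound 3 and compound 4 indistinguishable. This position therefore accepts a bromo group in place of hydrogen without a step beyond the scatter. Nothing available explains this result. The compounds shown leave open whether an amine, a carboxylic acid or a longer chain at this position would give a step beyond the scatter. They also leave open whether bromo would behave the same way without the neighbouring hydroxy group.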